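Swapping a tert-butyl ester for a benzyl ester

A few compounds are considered here, and "the series" means these few. Any claim that something is new, unique, unknown or untested is made for them only; others in the source may bear on it.

Two compounds share a core and differ only in one ester group. Compound 1 `CCOC(=O)C1=C(C)NC(C)=C(C(=O)OC(C)C)C1c1csc(-c2ccc(Cl)cc2)n1` carries an isopropyl ester, and in an assay on isolated protein for antagonist activity at Voltage-dependent L-type calcium channel subunit alpha-1C (Cavia porcellus), with a stated time of 15 min (on this read-out lower numbers stand for stronger inhibition and higher numbers for weaker inhibition), compound 1 gives 2550 nM. Compound 2 `CCOC(=O)C1=C(C)NC(C)=C(C(=O)OC(C)(C)C)C1c1csc(-c2ccc(Cl)cc2)n1` carries a tert-butyl ester instead, and in this assay compound 2 gives 91000 nM. The step of a 36-fold higher number from compound 1 to compound 2 (1.55 log units; beyond the scatter) shows that adding one methyl at this point greatly weakened inhibition, and it places compound 2 at the weaker end of the two numbers measured.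

Compound 3 `CCOC(=O)C1=C(C)NC(C)=C(C(=O)OCc2ccccc2)C1c1csc(-c2ccc(Cl)cc2)n1` is not yet measured. It differs from compound 2 by benzyl in place of tert-butyl on an oxygen next to a carbonyl group. Within the data shown here, no measured step covers this exact change; the only step that bears on it is a 36-fold higher number from compound 1 to compound 2 (1.55 log units; beyond the scatter), which shows that this ester position is very sensitive to what is attached. Since the benzyl group is not branched at the carbon bound to the oxygen, the potency is expected to recover toward that of compound 1. The step from compound 2 to compound 3 is therefore estimated as a 30-fold lower number from compound 2 to compound 3 (1.48 log units; beyond the scatter). Compound 3 is expected to give 3000 nM in this assay, with a range from 500 nM to 20000 nM.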

Compound 3, half-maximal inhibitory concentration: 3290 nM
Compound 3: middle estimate off by 1.1-fold (0.04 log units), on the low side, within the range that was stated.
By their numbers in this assay, from the lowest: compounds 1 and 3 (each within the scatter of the next); then compound 2.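

In this assay the step of a 28-fold lower number from compound 2 to compound 3 (1.44 log units; beyond the scatter) shows that the large loss seen with tert-butyl does not come with every bigger group at this ester oxygen: benzyl has 7 heavy atoms against 4 for tert-butyl, yet its number is far lower. The step of a 1.3-fold higher number from compound 1 to compound 3 (0.11 log units; within the scatter) lies within the scatter, so the isopropyl and benzyl esters cannot be told apart, and a six-membered aromatic ring can stand here without the loss that tert-butyl brings. Of these three esters, tert-butyl alone stands apart, and no measurement available here explains that difference.

The compounds shown leave open whether a longer chain ending in the same ring, such as a phenethyl ester, would keep a number close to those of compound 1 and compound 3. They also leave open how an ester carrying an amine, or a benzyl ring bearing a methoxy group, would fare at this position.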